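Halogen to hydroxypentyl on a shared oxadiazole-benzimidazole core

The source may report more compounds than this note shows. Statements on the series, on what has been measured and on what is new or still open speak of the compounds shown alone.

Compound 1 `FC(F)(F)c1ccccc1-c1nc(-c2ccc3nc[nH]c3c2)no1` gives 4.01 in a physicochemical assay for lipophilicity, using potentiometric titration, at pH 7.4; a higher number here means a more lipophilic compound, a lower number a more polar compound.
Compound 2 `Brc1ccc(-c2nc(-c3ccc4nc[nH]c4c3)no2)cc1` gives 3.54 in this assay.
Compound 3 `Clc1ccc(-c2nc(-c3ccc4nc[nH]c4c3)no2)cc1` gives 3.71 in this assay.

Compound 3 sits within the scatter of both neighbours: its nearest value is that of compound 2, its furthest that of compound 1, and neither gap is beyond the scatter. For the measured compounds named here, the single measured step, a number 0.17 log units higher from compound 2 to compound 3 (within the scatter), exchanges one halogen for another and does not bear directly on the change now considered.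

Compound 4 `OCCCCCc1ccc(-c2nc(-c3ccc4nc[nH]c4c3)no2)cc1` differs from compound 3 by 5-hydroxypentyl in place of chloro on an aromatic carbon. Going by the values given here, no measured pair replaces a halogen with a chain carrying a hydroxyl, so the expectation rests on the structural change alone. The five-carbon chain is expected to outweigh the hydroxyl it carries, so compound 4 is estimated to read a number 0.19 log units higher from compound 3 to compound 4 (within the scatter) in this assay, a modest rise that may still fall within the scatter. Compound 4 is therefore estimated at 3.9, with a range from 3.4 to 4.5.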

Compound 4, distribution coefficient: 3.51
Compound 4: middle estimate off by 0.39 log units, on the high side; the range from low to high includes it.
By their numbers in this assay, from the lowest: compounds 4, 2, 3 and 1 (each within the scatter of the next, the first and the last beyond it).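

For the compounds shown here, the only earlier step at this place exchanged one halogen for another, whereas here a chain carrying a hydroxyl replaces a halogen, and this assay shows a number 0.20 log units lower from compound 3 to compound 4 (within the scatter) when it replaces chloro and a number 0.03 log units lower from compound 2 to compound 4 (within the scatter) when it replaces bromo. On this shared core, then, a much larger group with a hydrogen-bond donor and acceptor leaves the number within the scatter of both halogen compounds. Nothing at hand explains why the chain and its hydroxyl together give this result.

Going by these compounds, what a plain pentyl chain, a shorter or longer hydroxyalkyl chain, or an amine at the end of the chain would read in this assay remains open. On these data alone, with it stays open how much the hydroxyl and the carbon chain each contribute to the number.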